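Diamine core series: added methoxy on the benzylamine ring

The compounds below may be only part of what the source reports. "The series", "measured", "known", "first", "only" and "open" are said of these compounds alone.

Compound 1 `COc1ccc(CNc2nc3cc(N)cc(N)c3nc2-c2ccccc2)cc1OC` is the reference point of this pair. Within the data shown here, in a functional assay on ACHN cells (Homo sapiens) for inhibition, read by sulforhodamine B assay, with a stated time of 48 h (a higher number here means that more compound is tolerated, a lower number that less compound is tolerated), compound 1 gives 81300 nM, and this is the only actual number in the set. Compound 2 `CCOC(=O)[C@H](CCC(=O)O)NC(=O)c1ccc(Sc2nc3cc(N)cc(N)c3nc2-c2ccccc2)cc1` carries a different side arm on the shared core and in this assay is reported as < 100000 nM, which is a limit of the assay rather than a number (the limit of < 100000 nM in this assay, at which 1 of the 2 values shown sits). So compound 1 stands as the sole measured point, with nothing measured to compare it against.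

Compound 3 `COc1cc(CNc2nc3cc(N)cc(N)c3nc2-c2ccccc2)cc(OC)c1OC` is yet to be measured in this assay. It differs from compound 1 by methoxy in place of hydrogen on an aromatic carbon. Among the measured compounds shown here, no measured step of this kind is available, so the expectation rests on the small size of the change alone. The step of a 1.2-fold lower number from compound 1 to compound 3 (0.06 log units; within the scatter) is expected to stay within the usual scatter, with no clear direction. Compound 3 is therefore estimated at 70000 nM in this assay, with a likely range from 30000 nM to 150000 nM.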

Compound 3, concentration lethal to 50% of the cells: 23400 nM
Compound 3: middle estimate off by 3.0-fold (0.48 log units), on the high side; the measured number lies below the stated range.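

Methoxy in place of hydrogen on an aromatic carbon, ortho to a methoxy group and meta to a large group, gives in this assay a 3.5-fold lower number from compound 1 to compound 3 (0.54 log units; beyond the scatter) and so shows that this position on the six-membered aromatic ring is not silent to the change. Among these compounds, this is the first measured step, and it shows a direction that the earlier compounds could not: the added methoxy goes with a lower number, meaning that less compound is tolerated, and the size of the step lies beyond the scatter. No measurement shown here gives a reason for this step.

From the compounds shown here alone, whether the step belongs to methoxy in particular stays open, since a hydroxyl, a fluorine, an amine or a longer ethoxy chain at the same position would be needed to separate the effect of this group from that of any substituent there. Compound 2 carries a different side arm and its < 100000 nM is a limit of the assay and not a number, so it gives no second reading of this step.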